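Lengthening a Side Chain by One Carbon

The compounds below may be only part of what the source reports. "The series", "measured", "known", "first", "only" and "open" are said of these compounds alone.

Compound 1 `CCCCCCC(CCO)n1cnc2c(N(C)C)ncnc21` and compound 2 `CCCCCCCC(CCO)n1cnc2c(N(C)C)ncnc21` share one core and differ by methyl in place of hydrogen on a saturated chain carbon, seven bonds along the chain from an aromatic nitrogen. In a functional assay on HCT-116 cells (Homo sapiens) for antiproliferative activity, read by MTT assay, with a stated time of 48 h (a higher number here means a weaker inhibitor, a lower number a stronger inhibitor), compound 1 reaches only the limit of > 50000 nM. Compound 2 likewise gives only the limit of > 50000 nM. The step that the two limits leave unreadable from compound 1 to compound 2 cannot be sized because both sit at the limit of > 50000 nM in this assay, at which 2 of the 3 values shown sit. Compound 3 `CCCCCCCCC(CCO)n1cnc2c(Cl)nc(F)nc21` carries another core; how it differs from the core of compound 1 is not broken down here. In this assay, for the measured compounds named here, compound 3 gives 24200 nM, the only number among the three. Compound 4 `CCCCCCCCCC(CCO)n1cnc2c(Cl)nc(F)nc21` differs from compound 3 by methyl in place of hydrogen on a saturated chain carbon, nine bonds along the chain from an aromatic nitrogen, the same kind of change as before, though here nine bonds along the chain from an aromatic nitrogen rather than seven. With the earlier step unreadable, the expected step of a 1.2-fold lower number from compound 3 to compound 4 (0.08 log units; within the scatter) rests only on compound 3 at 24200 nM and is kept small. Compound 4 is estimated at 20000 nM, between 8000 nM and 50000 nM.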

Compound 4, half-maximal inhibitory concentration: 32100 nM
Compound 4: middle estimate off by 1.6-fold (0.21 log units), on the low side; measured number inside the range.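

On the core of compound 3, the added methyl gives a 1.3-fold higher number from compound 3 to compound 4 (0.12 log units; within the scatter) in this assay, so no effect of the one-carbon extension can be told from scatter on this core. Compound 1 and compound 2 each give only a limit, and the step on their core cannot be read because of this: (the limit of > 50000 nM in this assay, at which 2 of the 4 values shown sit). The data therefore do not show whether the change carries from one core to the other, neither that it behaves alike on both nor that it differs.

Going by these compounds, it remains open whether a longer chain would give a readable number on either core. On these data alone, it is equally open how an amine or a carboxylic acid on the side chain would read in this assay on either core.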